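The compounds below may be only part of what the source reports. "The series", "measured", "known", "first", "only" and "open" are said of these compounds alone.

Measured compounds in an ADME assay on PC-3 cells (Homo sapiens) for cytotoxicity, read by WST assay, tested at 100 uM; on this read-out lower numbers stand for less inhibition and higher numbers for more inhibition at the one concentration tested (going by the name of the read-out):

- compound 1, `O=C(Nc1ccc(Cl)cc1)C1CCCN(C(=O)c2cccc([N+](=O)[O-])c2)C1`, gives 0%
- compound 2, `C=Cc1cccc(C(=O)N2CCCC(C(=O)Nc3ccc(Cl)cc3)C2)c1`, gives 0%

Compound 2 stands level with compound 1 at the digits shown: the step of no change at the digits printed from compound 1 to compound 2 (within the scatter) is within the scatter, so neither compound shows any inhibition of the cells at the concentration tested.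

Compound 3, `CCN(CC)S(=O)(=O)c1cccc(C(=O)N2CCCC(C(=O)Nc3ccc(Cl)cc3)C2)c1`, has not yet been measured in this assay. It differs from compound 2 in one place: diethylsulfamoyl in place of vinyl on an aromatic carbon.

Going by the values given here, only one measured step bears on this change, no change at the digits printed from compound 1 to compound 2 (within the scatter), where a group on an aromatic carbon was exchanged and the read-out did not move. Among the compounds with values here, the group entering in compound 3 is larger than either of the earlier groups, but the one piece of evidence available shows that exchanging the group at this place left the read-out unchanged. The expected step from compound 2 to compound 3 is therefore none beyond the scatter, a number 2 percentage points higher from compound 2 to compound 3 (within the scatter).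

Compound 3 is thus estimated at 2%, with a range from -8% to 15%.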

Compound 3, a percentage reported as inhibition, at one concentration (the size of the read-out at that concentration, not a potency): 0%
Compound 3: the middle estimate sits 2 percentage points above what was measured; the range from low to high includes it.
By their numbers in this assay, from the lowest: compounds 1, 2 and 3 (each within the scatter of the next).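

In this assay, the exchange of vinyl for diethylsulfamoyl shows no change at the digits printed from compound 2 to compound 3 (within the scatter), and the exchange of nitro for the same group shows no change at the digits printed from compound 1 to compound 3 (within the scatter). This aromatic carbon, meta to a large group, has now carried three different groups, including diethylsulfamoyl with its 8 heavy atoms and 2 hydrogen-bond acceptors, and the three compounds read alike at the one concentration tested. Nothing measured here explains this sameness.

From the compounds shown here alone, whether an amine or a carboxylic acid on the same carbon would also leave the read-out where it stands remains open. The compounds shown also say nothing about exchanging the chlorine elsewhere in the shared core, since all three carry it.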